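Working notes: from compound 2 to compound 3

A few compounds are considered here, and "the series" means these few. Any claim that something is new, unique, unknown or untested is made for them only; others in the source may bear on it.

In an ADME assay on J774.A1 cells (Mus musculus) for cytotoxicity, read by MTT assay, with a stated time of 72 h (a lower number here means that less compound is tolerated, a higher number that more compound is tolerated), compound 2 `CC1(c2ccc(-c3cccc([N+](=O)[O-])c3)cc2)CC(S(=O)(=O)c2ccc(F)cc2)=C(c2ccc(/C(N)=N\O)cc2)O1` gives 11100 nM, the higher of the two numbers, and compound 1 `CC1(c2ccc(-c3ccco3)cc2)CC(S(=O)(=O)c2ccc(F)cc2)=C(c2ccc(/C(N)=N\O)cc2)O1` gives 4560 nM. Compound 3 `Cc1ccc(-c2ccc(C3(C)CC(S(=O)(=O)c4ccc(F)cc4)=C(c4ccc(/C(N)=N\O)cc4)O3)cc2)cc1` differs from compound 2 by 4-methylphenyl in place of 3-nitrophenyl on an aromatic carbon, with 4-methylphenyl in place of 3-nitrophenyl on an aromatic carbon. For the measured compounds named here, the only measured step bearing on this is modest: a 2.4-fold higher number from compound 1 to compound 2 (0.39 log units; beyond the scatter), with 3-nitrophenyl in place of furan-2-yl. Going by the values given here, no measured compound carries 4-methylphenyl, so a small move toward a lower number is expected in this assay. The expected change is a 1.5-fold lower number from compound 2 to compound 3 (0.17 log units; within the scatter). For compound 3 the estimate is 7500 nM, with an expected range of 3500 nM to 15000 nM.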

Compound 3, half-maximal cytotoxic concentration: 7910 nM
For compound 3 the middle estimate is 1.1-fold (0.02 log units) below the measured one; the range from low to high includes it.
By their numbers in this assay, from the lowest: compounds 1, 3 and 2 (each within the scatter of the next, the first and the last beyond it).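

The exchange of 3-nitrophenyl for 4-methylphenyl at this position, para to a large group, gives a 1.4-fold lower number from compound 2 to compound 3 (0.15 log units; within the scatter) in this assay and does not separate the two groups. Against furan-2-yl, 4-methylphenyl gives a 1.7-fold higher number from compound 1 to compound 3 (0.24 log units; within the scatter) and so, unlike 3-nitrophenyl, stays within the scatter. Nothing at hand accounts for these numbers. The compounds shown leave open whether an aromatic group carrying an amine or a carboxylic acid at this position would give a number beyond the scatter of all three.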